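Replacing the sulfonylpiperazine with hydroxypiperidine on the azetidine

The source may hold more compounds than are shown below. What is called first, only, known or untested is meant among the compounds shown, and "the series" means these compounds.

Measured so far:
Compound 1 `CC(=O)N1CCN(C2CN(CCC3(c4ccc(Cl)c(Cl)c4)CCC(=O)N(Cc4ccccc4)C3)C2)CC1` — 1.59 nM
Compound 2 `CS(=O)(=O)N1CCN(C2CN(CCC3(c4ccc(Cl)c(Cl)c4)CCC(=O)N(Cc4ccccc4)C3)C2)CC1` — 0.631 nM

Both compounds share one core and differ only in the group on the amine nitrogen of the piperazine ring. In an assay on isolated protein (artery, Oryctolagus cuniculus) with Substance-P receptor (Homo sapiens) as the target (a lower number here means tighter binding, a higher number weaker binding), compound 1 gives 1.59 nM; compound 2 gives 0.631 nM. Among the compounds with values here, the single step in hand is a 2.5-fold lower number from compound 1 to compound 2 (0.40 log units; beyond the scatter). Within the data shown here, compound 2 therefore stands lowest of the two numbers in this assay, with compound 1 as its only neighbour.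

Compound 3 `O=C1CCC(CCN2CC(N3CCC(O)CC3)C2)(c2ccc(Cl)c(Cl)c2)CN1Cc1ccccc1` has not yet been measured. It differs from compound 2 as follows: 4-hydroxypiperidin-1-yl in place of 4-(methylsulfonyl)piperazin-1-yl on a saturated ring carbon. Among the measured compounds shown here, the change removes the whole piperazine ring together with its methylsulfonyl group and brings in a hydroxyl-bearing piperidine, so the one measured step, which only swapped the group on the piperazine nitrogen, bears on it at best indirectly; it shows that the series tolerates a modest shift at this end of the molecule. Nothing measured addresses the loss of the sulfonyl.

Compound 3 is expected to give about 1.5 nM in this assay, within 0.5 nM to 5 nM. The estimated step is a 2.4-fold higher number from compound 2 to compound 3 (0.38 log units; beyond the scatter), a modest weakening.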

Compound 3, dissociation constant: 0.0794 nM
Compound 3: middle estimate off by 19-fold (1.28 log units), on the high side; measured number below the stated range.
By their numbers in this assay, from the lowest: compound 3; then compound 2; then compound 1.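

In this assay the exchange of 4-(methylsulfonyl)piperazin-1-yl for 4-hydroxypiperidin-1-yl gives a 7.9-fold lower number from compound 2 to compound 3 (0.90 log units; beyond the scatter) on the saturated ring carbon of the four-membered ring, and the same exchange from 4-acetylpiperazin-1-yl gives a 20-fold lower number from compound 1 to compound 3 (1.30 log units; beyond the scatter) at the same place. Within the data shown here, the earlier pair showed only what the group on the piperazine nitrogen does, with a 2.5-fold lower number from compound 1 to compound 2 (0.40 log units; beyond the scatter) as its one step, whereas these steps show that the whole piperazine can leave this position, along with its sulfonyl or acetyl group, and the number still goes down. Nothing at hand bears on the reason for this gain.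

The compounds shown do not separate the hydroxyl from the loss of the piperazine ring, so it stays open whether plain piperidine, 4-methoxypiperidine or 4-aminopiperidine would hold the low number seen for compound 3. From the compounds shown here alone, it is also open whether the gain depends on the hydroxyl sitting at the 4-position of a six-membered ring, a question that 3-hydroxypiperidine or 3-hydroxypyrrolidine at the same ring carbon would address.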